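The source may report more compounds than this note shows. Statements on the series, on what has been measured and on what is new or still open speak of the compounds shown alone.

In a functional assay on U-937 cells (Homo sapiens) for antiproliferative activity, read by MTT assay, with a stated time of 72 h (on this read-out higher numbers stand for weaker inhibition and lower numbers for stronger inhibition), the measured compounds give:

- compound 1 `Cc1ccc(-c2noc(CCCCCCC(=O)NO)n2)cc1` with 1360 nM
- compound 2 `O=C(CCCCCCc1nc(-c2ccc(F)cc2)no1)NO` with 1930 nM
- compound 3 `O=C(CCCCCCc1nc(-c2cccs2)no1)NO` with 320 nM

On these numbers, compound 1 cannot be told apart from compound 2, as the comparison shows a 1.4-fold higher number from compound 1 to compound 2 (0.15 log units; within the scatter) and only compound 3 stands clear, with a 4.3-fold lower number from compound 1 to compound 3 (0.63 log units; beyond the scatter) on the same read-out.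

The next molecule, compound 4 `Cc1ccc(-c2noc(CCCCCCC(=O)Nc3ccccc3N)n2)cc1`, keeps the core of compound 1 and alters the other end of the chain: 2-aminophenyl in place of hydroxy on an amide-type nitrogen in a swap of hydroxyamino for (2-aminophenyl)amino.

Among the measured compounds shown here, no measured step touches this amide-type nitrogen. All three changes sit on an aromatic carbon, so they indicate only how far a single change has moved the numbers in this series. The largest is a 6.0-fold lower number from compound 2 to compound 3 (0.78 log units; beyond the scatter) and it offers no direction here. A much larger group enters than leaves, so a modest move towards weaker inhibition is expected, but this remains a judgement rather than a measured trend.

The expected change is a 2.2-fold higher number from compound 1 to compound 4 (0.34 log units; beyond the scatter) and it is an uncertain estimate.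

Compound 4 is estimated at 3000 nM in this assay, with an expected range from 800 nM to 11000 nM before the measurement is known.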

Compound 4, half-maximal inhibitory concentration: 460 nM
For compound 4 the middle estimate is 6.5-fold (0.81 log units) above the measured one; the measured number lies below the stated range.
By their numbers in this assay, from the lowest: compounds 3 and 4 (each within the scatter of the next); then compounds 1 and 2 (each within the scatter of the next).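

Swapping hydroxyamino for (2-aminophenyl)amino gives in this assay a 3.0-fold lower number from compound 1 to compound 4 (0.47 log units; beyond the scatter) and so the amide-type nitrogen, which no earlier step touched, takes a far larger group with stronger inhibition rather than weaker. In this pair, therefore, the hydroxy group is not needed for antiproliferative activity on these cells, whereas the earlier steps had only shown changes on an aromatic carbon. Nothing shown gives a reason for this gain.

Going by these compounds, whether the same swap would also strengthen inhibition on the thiophen-2-yl compound 3 or the 4-fluorophenyl compound 2 remains open. So does the role of the amine in the 2-aminophenyl group, which a plain phenyl group on the same nitrogen would test.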